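Two Aryl Variants at the Toxicity Limit, a Third Estimated

The compounds below may be only part of what the source reports. "The series", "measured", "known", "first", "only" and "open" are said of these compounds alone.

Measured so far:
- compound 1 `Cc1nc(-c2cccnc2)sc1-c1nnc(-c2ccc(Br)cc2)o1` — in an ADME assay on HCT-116 cells (Homo sapiens) for cytotoxicity, read by MTT assay (on this read-out higher numbers stand for lower toxicity in this test and lower numbers for higher toxicity in this test), compound 1 gives > 100 ug/mL, a limit of the assay.
- compound 2 `Cc1nc(-c2cccnc2)sc1-c1nnc(-c2cccc(Cl)c2Cl)o1` — in this assay compound 2 gives > 100 ug/mL, likewise a limit of the assay.

Compound 2 therefore stands only at a limit, not at a number, and the other value shown is a limit as well. The step that the two limits leave unreadable from compound 1 to compound 2 cannot be read, as the limit of > 100 ug/mL in this assay, at which 2 of the 2 values shown sit, states. Compound 3 `Cc1cccc(-c2nnc(-c3sc(-c4cccnc4)nc3C)o2)c1` differs from compound 2 by 3-methylphenyl in place of 2,3-dichlorophenyl on an aromatic carbon. Among the measured compounds shown here, no measured step gives a readable size for an aryl exchange at this position, so no step beyond the scatter in this assay can be predicted in either direction. Compound 3 is accordingly expected to give about 120 ug/mL, between 50 ug/mL and 300 ug/mL, most likely again as a limit. The step that the limit leaves unreadable from compound 2 to compound 3 is thus estimated to stay within the scatter.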

Compound 3, half-maximal cytotoxic concentration: > 100 ug/mL
Compound 3 was reported as a limit; the forecaster's own chance of this, stated with the estimate: 75%; the middle value lies beyond the limit too.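

Compound 3 sits at a limit in this assay just as compound 1 and compound 2 do, so no step among these three compounds can be read: the limit of > 100 ug/mL in this assay, at which 3 of the 3 values shown sit. The compounds shown leave open whether exchanging the aryl group at this position changes toxicity in this test at all.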